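The compounds below may be only part of what the source reports. "The series", "measured", "known", "first", "only" and "open" are said of these compounds alone.

Measured so far in an assay on isolated protein for displacement of a labelled ligand from metabotropic glutamate receptor 5 (Homo sapiens), with a stated time of 60 min, tested at 1 uM; a lower number here means less inhibition, a higher number more inhibition at the concentration tested (going by the name of the read-out):
Compound 1 `COc1ccc(S(=O)(=O)c2cnc3ccc(F)cc3c2N2CCC(C)CC2)cc1` gives 85%.
Compound 2 `COc1ccc2ncc(S(=O)(=O)c3ccc(C)c(F)c3)c(N3CCC(C)CC3)c2c1` gives 73%.
Compound 3 `CC1CCN(c2c(S(=O)(=O)c3ccc(F)c(Cl)c3)cnc3cc(F)ccc23)CC1` gives 94%.

Compound 1 stands second highest of the three numbers. Its nearest neighbour is compound 3, whose number is higher but within the scatter, so no order between the two is claimed. Compound 2 sits lower than compound 1 by a gap beyond the scatter. Compound 4 `Cc1cc(C)cc(S(=O)(=O)c2cnc3ccc(F)cc3c2N2CCC(C)CC2)c1` is not yet measured; it carries 3,5-dimethylphenyl in place of 4-methoxyphenyl on a sulfonyl sulfur. For the measured compounds named here, no single-change step between measured compounds is available to calibrate this exchange, and all three measured numbers fall in the upper part of the scale. The step in this assay from compound 1 is therefore expected to be small, in either direction or none beyond the scatter. Compound 4 is expected to give 80% in this assay, within 60% to 95%, meaning a step of a number 5 percentage points lower from compound 1 to compound 4 (within the scatter).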

Compound 4, a percentage reported as inhibition, at one concentration (the size of the read-out at that concentration, not a potency): 83%
The estimate for compound 4 lay 3 percentage points below the measured number; low and high end bracket the measured number.
By their numbers in this assay, from the lowest: compounds 2, 4, 1 and 3 (each within the scatter of the next, the first and the last beyond it).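

In this assay, for the compounds shown here, 3,5-dimethylphenyl in place of 4-methoxyphenyl on a sulfonyl sulfur gives a number 2 percentage points lower from compound 1 to compound 4 (within the scatter) as the first single-change step. At this position, an all-carbon aryl group without a hydrogen-bond acceptor therefore serves as well as 4-methoxyphenyl, within the scatter of this single-concentration read-out. No measurement at hand bears on why the step is this small.

Open, going by these compounds, is how far this position accepts other groups on the sulfonyl sulfur, such as a phenyl ring carrying a carboxylic acid or an amine, or a saturated cyclohexyl ring. Also open, on these data alone, is whether compound 1 and compound 4 would stay this close in a full concentration series.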